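The source may hold more compounds than are shown below. What is called first, only, known or untested is meant among the compounds shown, and "the series" means these compounds.

In a functional assay on the whole organism (trachea) with Rattus norvegicus as the target (on this read-out higher numbers stand for larger maximal responses and lower numbers for smaller maximal responses), compound 2 `COc1ccc(NS(=O)(=O)c2ccc3c(c2)C(n2ccccc2=O)=CC(C)(C)O3)cc1` gives 84.2%, the lower of the two numbers measured. Compound 1 `CC(C)NS(=O)(=O)c1ccc2c(c1)C(n1ccccc1=O)=CC(C)(C)O2` gives 94.8%, and the step of a number 10.6 percentage points lower from compound 1 to compound 2 (beyond the scatter) came with 4-methoxyphenyl in place of isopropyl on a sulfonamide nitrogen. Compound 3 `CC1(C)C=C(n2ccccc2=O)c2cc(S(=O)(=O)Nc3ccc([N+](=O)[O-])cc3)ccc2O1` differs from compound 2 by nitro in place of methoxy on an aromatic carbon. Within the data shown here, the single measured step exchanges whole groups on the sulfonamide nitrogen, and no step yet tests an exchange on an aromatic carbon, so it does not bear on this change. The expected step is therefore a number 0.2 percentage points lower from compound 2 to compound 3 (within the scatter), within the scatter. The estimate for compound 3 in this assay is 84%, ranging from 68% to 97%.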

Compound 3, largest response reached (Emax), in percent of the reference or control that the assay uses: 75.6%
Compound 3: the middle estimate sits 8.4 percentage points above what was measured; the measured number falls inside the stated range.
By their numbers in this assay, from the lowest: compounds 3 and 2 (each within the scatter of the next); then compound 1.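

In this assay, the first exchange tested on this aromatic carbon, para to a large group, came with a number 8.6 percentage points lower from compound 2 to compound 3 (within the scatter), so methoxy and nitro are not told apart here. On the sulfonamide nitrogen, 4-nitrophenyl in place of isopropyl came with a number 19.2 percentage points lower from compound 1 to compound 3 (beyond the scatter), so compound 3, like compound 2, stands beyond the scatter from compound 1. Nothing available accounts for these numbers. As far as these compounds go, whether an amine or a carboxylic acid on this aromatic carbon would stand beyond the scatter from compound 2 remains open.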